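Changing the amine on a carbonyl carbon

The compounds below may be only part of what the source reports. "The series", "measured", "known", "first", "only" and "open" are said of these compounds alone.

Going by the values given here, in a functional assay on U-937 cells (Homo sapiens) for antiproliferative activity, read by MTT assay, with a stated time of 24 h (a lower number here means a stronger inhibitor, a higher number a weaker inhibitor), compound 1 `CCCCNC(=O)CCCOc1ccc(C(=O)c2c(CCCC)oc3ccccc23)cc1` gives 24600 nM and compound 2 `CCCCc1oc2ccccc2c1C(=O)c1ccc(OCCCC(=O)N(C)Cc2ccccc2)cc1` gives 10500 nM, the lower of the two numbers so far. Compound 3 `CCCCc1oc2ccccc2c1C(=O)c1ccc(OCCCC(=O)N[C@H](C)c2ccccc2)cc1` carries (1-phenylethyl)amino in place of the benzyl(methyl)amino of compound 2 on a carbonyl carbon: (1-phenylethyl)amino in place of benzyl(methyl)amino on a carbonyl carbon. Among the compounds with values here, one measured step bears on this change: a 2.3-fold lower number from compound 1 to compound 2 (0.37 log units; beyond the scatter), modest but beyond the scatter, with butylamino replaced by benzyl(methyl)amino at the same place. Within the data shown here, compound 3 shares an aromatic ring with compound 2 and an amide hydrogen with compound 1, and no measured compound separates these two features. A single step is thin evidence, so only a small rise is expected in this assay, within the scatter. The estimated change is a 1.3-fold higher number from compound 2 to compound 3 (0.12 log units; within the scatter). Compound 3 is expected at about 14000 nM, with an estimated range of 6000 nM to 30000 nM.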

Compound 3, half-maximal inhibitory concentration: 30700 nM
The estimate for compound 3 lay 2.2-fold (0.34 log units) below the measured number; measured number above the stated range.
By their numbers in this assay, from the lowest: compound 2; then compounds 1 and 3 (each within the scatter of the next).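

In this assay, replacing benzyl(methyl)amino with (1-phenylethyl)amino keeps the same atoms and the aromatic ring but adds an amide hydrogen and a defined stereocentre, and the result is a 2.9-fold higher number from compound 2 to compound 3 (0.47 log units; beyond the scatter). An aromatic ring on this amide therefore does not by itself keep the number low, and exchanging butyl for 1-phenylethyl on the amide-type nitrogen gives only a 1.2-fold higher number from compound 1 to compound 3 (0.10 log units; within the scatter), so both compounds that keep the amide hydrogen stand apart from compound 2. Nothing in the available data explains why these two arrangements of the same atoms differ.

Compound 2 and compound 3 differ both in the methyl on the nitrogen and in the branched carbon, so these two changes cannot be separated. From the compounds shown here alone, a plain benzylamino group, or 1-phenylethylamino with the opposite stereocentre, could help tell them apart, and how either would read remains open.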